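Swapping the pyrimidine for a bicyclic amine in compound 1

This account rests on a few compounds, and the source may have more. Where it says the series, first, only, none or still open, it means among the compounds named here.

Measured compounds:
compound 1, `C[C@H](Nc1nc(N)nc(N)c1C#N)c1nn(-c2cccc(S(C)(=O)=O)c2)c2cc(F)ccc12`: 24%
compound 2, `C[C@H](Nc1ncnc2[nH]cnc12)c1nn(-c2cccnc2)c2ccc(F)cc12`: 8%
compound 3, `C[C@H](Nc1nc(N)nc(N)c1C#N)c1nn(-c2cccc(S(C)(=O)=O)c2)c2cc(Cl)ccc12`: 56%

In a functional assay on HepG2 cells (Homo sapiens) for inhibition, read by sulforhodamine B assay, with a stated time of 72 h, tested at 10 uM (on this read-out higher numbers stand for more inhibition at the one concentration tested (going by the name of the read-out) and lower numbers for less inhibition), compound 1 stands second of the three numbers, sitting between compound 2 and compound 3. For the measured compounds named here, the only measured step, a number 32 percentage points higher from compound 1 to compound 3 (beyond the scatter), changes the halogen, not the amine substituent.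

Compound 4, `C[C@H](Nc1ncnc2[nH]cnc12)c1nn(-c2cccc(S(C)(=O)=O)c2)c2cc(F)ccc12`, differs from compound 1 at the amine: a group of 9 heavy atoms (5 carbon, 4 nitrogen; one five-membered aromatic ring with 2 hetero atoms, one six-membered aromatic ring with 2 hetero atoms) in place of a group of 10 heavy atoms (5 carbon, 5 nitrogen; one six-membered aromatic ring with 2 hetero atoms), on an amine nitrogen

Going by the values given here, no measured step covers this change. Compound 2 carries the same entering group but differs in other places too, and gives the lowest value shown. On that thin basis the step of a number 12 percentage points lower from compound 1 to compound 4 (beyond the scatter) is expected to be downward, modestly. Compound 4 is estimated at 12%, within 0% to 30%.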

Compound 4, a percentage reported as inhibition, at one concentration (the size of the read-out at that concentration, not a potency): 23%
Beside the measured number, compound 4's estimate is 11 percentage points below it; measured number inside the range.
By their numbers in this assay, from the lowest: compound 2; then compounds 4 and 1 (each within the scatter of the next); then compound 3.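

In this assay, putting the two-ring group in place of 2,6-diamino-5-cyanopyrimidin-4-yl on the amine nitrogen gives a number 1 percentage points lower from compound 1 to compound 4 (within the scatter). At this position, with the fluoro core of compound 1, the two groups therefore cannot be told apart in this assay, even though they differ in ring count and in hydrogen-bond donors and acceptors. No measurement here explains this result.

Going by these compounds, it remains open whether the same exchange would give a similar result on the chloro core of compound 3. On these data alone, it is also open how a simple phenyl ring or a morpholine on that amine nitrogen would read.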